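The compounds below may be only part of what the source reports. "The series", "measured", "known", "first", "only" and "open" are said of these compounds alone.

Compound 2 `C=CC(=O)Nc1cccc(Nc2nc(Nc3ccc(-n4ccnc4)cc3)ncc2[N+](=O)[O-])c1`: 12400 nM
Compound 1 `C=CC(=O)Nc1cccc(Nc2nc(Nc3ccc(OCCn4ccnc4)cc3)ncc2F)c1`: 2480 nM

In a functional assay on A-431 cells (Homo sapiens) for antiproliferative activity, read by MTT assay, with a stated time of 48 h (on this read-out lower numbers stand for stronger inhibition and higher numbers for weaker inhibition), compound 2 gives 12400 nM, the higher of the two numbers, and compound 1 gives 2480 nM, a gap beyond the usual scatter. Compound 3 `C=CC(=O)Nc1cccc(Nc2nc(Nc3ccc(OCCCn4ccnc4)cc3)ncc2[N+](=O)[O-])c1` has not been measured. It differs from compound 2 by 3-(1H-imidazol-1-yl)propoxy in place of 1H-imidazol-1-yl on an aromatic carbon, on an aromatic carbon of a six-membered aromatic ring of carbon only, para to a large group. Since compound 1, which also carries its imidazole through an oxygen-bearing chain, shows the lower value 2480 nM, a moderate fall in the number is expected, as the step of a 2.5-fold lower number from compound 2 to compound 3 (0.39 log units; beyond the scatter). Compound 3 is expected to give 5000 nM, within a range from 1500 nM to 16000 nM.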

Compound 3, half-maximal inhibitory concentration: 6460 nM
Compound 3: the middle estimate sits 1.3-fold (0.11 log units) below what was measured; low and high end bracket the measured number.
By their numbers in this assay, from the lowest: compound 1; then compounds 3 and 2 (each within the scatter of the next).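

In this assay the switch at this place, on the aromatic carbon para to a large group, from 1H-imidazol-1-yl to 3-(1H-imidazol-1-yl)propoxy gives a 1.9-fold lower number from compound 2 to compound 3 (0.28 log units; within the scatter) and so leaves the two compounds indistinguishable. This position therefore tolerates the larger group, with its added chain and oxygen, without a clear shift in the number.

On these data alone, whether a morpholine or a carboxylic acid on the same chain would shift the number beyond the scatter remains open. No measurement here explains the result.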